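A few compounds are considered here, and "the series" means these few. Any claim that something is new, unique, unknown or untested is made for them only; others in the source may bear on it.

Measured compounds:
compound 1, `Cc1cc(OCc2cccc(F)c2)ccc1CN[C@@H](C)C(N)=O`, 69 nM
compound 2, `NC(=O)C1CN(Cc2ccc(OCc3cccc(F)c3)cc2)C1`, 1420 nM

Both compounds were tested in an assay on Sf9 cells for inhibition of Amine oxidase [flavin-containing] B (Homo sapiens), with stated times of 15 min and 60 min; on this read-out higher numbers stand for weaker inhibition and lower numbers for stronger inhibition. Compound 1 gives 69 nM, while compound 2 gives 1420 nM, the highest number of the two and far apart from the number of compound 1, a gap beyond the usual scatter. Compound 1 and compound 2 differ in more than one place, so this gap is not tied to a single change.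

The account now turns to compound 3, `NC(=O)[C@@H]1CCCN1Cc1ccc(OCc2cccc(F)c2)cc1`, not yet measured. It differs from compound 2 in one place: 2-carbamoylpyrrolidin-1-yl in place of 3-carbamoylazetidin-1-yl on a saturated chain carbon bound to an aromatic carbon. In compound 3 the carboxamide again sits on the ring carbon directly bound to the ring nitrogen, as the carboxamide of compound 1 sits on the chain carbon bound to the amine nitrogen.

Compound 3 is expected to give a lower number than compound 2 in this assay, that is stronger inhibition, with a step of a 5.7-fold lower number from compound 2 to compound 3 (0.75 log units; beyond the scatter) expected to lie beyond the scatter. Compound 3 is estimated at 250 nM, with a range from 60 nM to 1000 nM.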

Compound 3, half-maximal inhibitory concentration: 204 nM
Compound 3: the middle estimate sits 1.2-fold (0.09 log units) above what was measured; the range from low to high includes it.
By their numbers in this assay, from the lowest: compound 1; then compound 3; then compound 2.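

In this assay, among these compounds, putting 2-carbamoylpyrrolidin-1-yl in place of 3-carbamoylazetidin-1-yl on a saturated chain carbon bound to an aromatic carbon gives a 7.0-fold lower number from compound 2 to compound 3 (0.84 log units; beyond the scatter) and is the first step that can be tied to a single change. It shows that the number at this position depends on which carboxamide-bearing ring is attached, but the swap alters the ring size and the ring carbon that carries the carboxamide and adds a defined stereocentre all at once, so the step belongs to the swap as a whole. No other measurement bears on this result.

Which of these three features carries the step remains open, as does whether the opposite configuration at the stereocentre or a six-membered ring bearing the carboxamide would shift the number further. Also open, as far as these compounds go, is whether a carboxylic acid or a nitrile in place of the carboxamide would keep compound 3 near 204 nM in this assay.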